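Phenyl in Place of Pyridin-2-yl on Compound 2

This account rests on a few compounds, and the source may have more. Where it says the series, first, only, none or still open, it means among the compounds named here.

In a functional assay on the whole organism with Mus musculus as the target, in the maximal electroshock model (a lower number here means that less compound is needed, a higher number that more compound is needed for the effect), the three measured compounds gave the following numbers:
compound 1 `Clc1ccc(-n2nncc2-c2cccnc2)cc1` — 65.8 mg/kg
compound 2 `Clc1ccc(-n2nncc2-c2ccccn2)cc1` — 95.3 mg/kg
compound 3 `c1ccc(-n2nncc2-c2ccccn2)cc1` — 41.1 mg/kg

Compound 2 stands apart from compound 1 by a 1.4-fold higher number from compound 1 to compound 2 (0.16 log units; within the scatter) and from compound 3 by a 2.3-fold lower number from compound 2 to compound 3 (0.37 log units; beyond the scatter). Compound 4 `Clc1ccc(-n2nncc2-c2ccccc2)cc1` differs from compound 2 in one place: phenyl in place of pyridin-2-yl on an aromatic carbon. Among the measured compounds shown here, no measured step removes the ring nitrogen altogether; the step from compound 1 to compound 2 moves it and stays within the scatter, and the step from compound 2 to compound 3 concerns the chloro group instead. A small change in this assay, if any, is therefore expected, with a slight lean towards a lower number, as a 1.3-fold lower number from compound 2 to compound 4 (0.10 log units; within the scatter). Compound 4 is estimated at 75 mg/kg, within 35 mg/kg to 160 mg/kg.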

Compound 4, dose for half-maximal effect: 233 mg/kg
Compound 4: middle estimate off by 3.1-fold (0.49 log units), on the low side; the whole stated range lies below it.
By their numbers in this assay, from the lowest: compounds 3, 1 and 2 (each within the scatter of the next, the first and the last beyond it); then compound 4.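

In this assay the ring nitrogen at this place proves to count: replacing pyridin-2-yl by phenyl gives a 2.4-fold higher number from compound 2 to compound 4 (0.39 log units; beyond the scatter) and replacing pyridin-3-yl by phenyl gives a 3.5-fold higher number from compound 1 to compound 4 (0.55 log units; beyond the scatter), whereas moving the nitrogen gave only a 1.4-fold higher number from compound 1 to compound 2 (0.16 log units; within the scatter) here. Both pyridinyl groups thus stand apart from phenyl, while remaining within the scatter of each other. Nothing at hand gives a reason for this. As far as these compounds go, whether the same holds with hydrogen in place of chloro stays open, as does how an amine or a methoxy group would read at this place.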